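Swapping the Enone Arm for a Methylpiperazine

The source may hold more compounds than are shown below. What is called first, only, known or untested is meant among the compounds shown, and "the series" means these compounds.

In a functional assay on MGC-803 cells (Homo sapiens) for inhibition, read by sulforhodamine B assay, with a stated time of 72 h, tested at 10 uM (on this read-out lower numbers stand for less inhibition and higher numbers for more inhibition at the one concentration tested (going by the name of the read-out)), compound 1 `Cc1cc(Nc2ccc(C(=O)/C=C/c3ccc(Br)cn3)cc2)n2nc(SCc3nc4ccccc4[nH]3)nc2n1` gives 96.8%, and compound 2 `Cc1cc(Nc2ccc(C(=O)/C=C/c3ccccc3)cc2)n2nc(SCc3nc4ccccc4[nH]3)nc2n1` gives 94.5%, the lower of the two numbers yet within the scatter of compound 1, as the step of a number 2.3 percentage points lower from compound 1 to compound 2 (within the scatter) shows. Compound 3 `Cc1cc(Nc2ccc(N3CCN(C)CC3)cc2)n2nc(SCc3nc4ccccc4[nH]3)nc2n1` differs from compound 2 by 4-methylpiperazin-1-yl in place of (2-phenylethenyl)carbonyl on an aromatic carbon. For the measured compounds named here, no measured step touches this change: the only step on record alters the aryl on the chain, not the chain itself, so it gives no guide. With the whole chain removed, the inhibition is expected to fall, the estimated step being a number 39.5 percentage points lower from compound 2 to compound 3 (beyond the scatter). Compound 3 is therefore expected to give about 55%, within 20% to 90%.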

Compound 3, a percentage reported as inhibition, at one concentration (the size of the read-out at that concentration, not a potency): 78.1%
Compound 3: the middle estimate sits 23.1 percentage points below what was measured, within the range that was stated.
By their numbers in this assay, from the lowest: compound 3; then compounds 2 and 1 (each within the scatter of the next).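

Putting 4-methylpiperazin-1-yl on this aromatic carbon in place of the whole arm lowers the reading in this assay, with a number 16.4 percentage points lower from compound 2 to compound 3 (beyond the scatter) and a number 18.7 percentage points lower from compound 1 to compound 3 (beyond the scatter). Changing the arm as a whole therefore moves the number beyond the scatter, which the aryl swap on the chain did not, yet compound 3 keeps 78.1% with no such chain at all. Nothing measured here accounts for the drop. On these data alone, it remains open whether a morpholine or a dimethylamino group at this carbon would read differently, and whether a carbonyl alone would restore the inhibition.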